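A few compounds are considered here, and "the series" means these few. Any claim that something is new, unique, unknown or untested is made for them only; others in the source may bear on it.

Series notes. Among the compounds with values here, in an assay on isolated protein for inhibition of Rho-associated protein kinase 1 (Homo sapiens), read by scintillation counting, radiometric assay and 33P incorporation, with a stated time of 40 min, in the presence of a further agent that is not named here (on this read-out higher numbers stand for weaker inhibition and lower numbers for stronger inhibition), compound 3 `CCCc1ccc(C(=O)Nc2cccc(NC(=O)COc3ccc4c(=O)ccoc4c3)c2)cc1` gives 143 nM, the only number obtained. Compound 1 `CN(C)c1ccc(C(=O)Nc2cccc(NC(=O)COc3ccc4c(c3)CCC(=O)N4)c2)cc1` returns the limit > 10000 nM. Compound 2 `CN(C)c1ccc(C(=O)Nc2cccc(NC(=O)COc3ccc4occc(=O)c4c3)c2)cc1` likewise returns the limit > 10000 nM. The step that the two limits leave unreadable from compound 1 to compound 2 cannot be read because of the limit of > 10000 nM in this assay, at which 2 of the 3 values shown sit. Compound 4 `Cn1ccc(S(=O)(=O)Nc2cccc(NC(=O)COc3ccc4c(=O)ccoc4c3)c2)n1` differs from compound 3 in that (a group of 9 heavy atoms (4 carbon, 2 nitrogen, 2 oxygen, 1 sulfur; one five-membered aromatic ring with 2 hetero atoms) in place of a group of 11 heavy atoms (10 carbon, 1 oxygen; one six-membered aromatic ring of carbon only), on a nitrogen on an aromatic ring). Within the data shown here, no measured step touches this position, so nothing measured sets the size or direction of the change expected in this assay. Compound 4 is therefore estimated at 1500 nM, with an expected range of 200 nM to 10000 nM. The step of a 10-fold higher number from compound 3 to compound 4 (1.02 log units; beyond the scatter) is expected with low confidence, toward weaker inhibition.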

Compound 4, half-maximal inhibitory concentration: > 10000 nM
Compound 4: no number, only a limit; the forecaster's own chance of this, stated with the estimate: 30%; middle value at least 6.6-fold (0.82 log units) away from the limit.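

In this assay, within the data shown here, putting the group with a five-membered aromatic ring with 2 hetero atoms in place of the (4-propylphenyl)carbonyl on the nitrogen gives an at least 69-fold higher number from compound 3 to compound 4 (1.84 log units; beyond the scatter), the first readable step at this position. From the compounds shown here alone, compound 4 gives > 10000 nM, which is a limit and not a number, so the step's true size stays unknown. The position therefore does not tolerate this change, and the series now mostly rests on one ceiling: the limit of > 10000 nM in this assay, at which 3 of the 4 values shown sit.

Going by these compounds, the step replaces the ring and the carbonyl together, so the share of each remains open. A benzenesulfonyl group on that nitrogen would separate the two.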